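Swapping a Trifluoromethyl Oxadiazole for an Ethoxycarbamoyl Group

The compounds below may be only part of what the source reports. "The series", "measured", "known", "first", "only" and "open" are said of these compounds alone.

Compound 1 `CC(CCOc1ccc(-c2noc(C(F)(F)F)n2)cc1)CCN1CCN(c2ccnc(N)c2)C1=O` was tested in an ADME assay on RD cells (Homo sapiens) for cytotoxicity, read by MTT assay, with a stated time of 24 h (a higher number here means that more compound is tolerated, a lower number that less compound is tolerated), and gave 48100 nM. Among the two measured compounds this is the only true number in this assay. Compound 2 `CCO/N=C/c1ccc(OCC#CCN2CCN(c3ccnc(N)c3)C2=O)cc1` gave > 100000 nM in this assay, and that value is a limit of the assay rather than a number. Going by the values given here, the only other value shown therefore sits at the limit of > 100000 nM in this assay, at which 1 of the 2 values shown sits, so compound 1 stands alone as the single measured point.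

Compound 3 `CCONC(=O)c1ccc(OCCC(C)CCN2CCN(c3ccnc(N)c3)C2=O)cc1` differs from compound 1 in one place: ethoxycarbamoyl in place of 5-(trifluoromethyl)-1,2,4-oxadiazol-3-yl on an aromatic carbon. Among the compounds with values here, no step between two measured compounds shows how such a change plays out here, so any expectation rests on compound 1 alone. The replacement of the 5-(trifluoromethyl)-1,2,4-oxadiazol-3-yl group by the ethoxycarbamoyl group is expected to move this assay upward by a modest step, perhaps no further than the usual scatter, with a fair chance that only a limit is returned. Compound 3 is accordingly expected to give 80000 nM in this assay, within a range from 30000 nM to 200000 nM. This estimate means a step of a 1.7-fold higher number from compound 1 to compound 3 (0.22 log units; within the scatter) in this assay.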

Compound 3, half-maximal cytotoxic concentration: > 100000 nM
Compound 3: no number, only a limit; the forecaster's own chance of this, stated with the estimate: 40%; middle value at least 1.2-fold (0.09 log units) from the limit.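

In this assay, the position on the aromatic carbon para to a large group now has a readable step: ethoxycarbamoyl in place of 5-(trifluoromethyl)-1,2,4-oxadiazol-3-yl gives an at least 2.0-fold higher number from compound 1 to compound 3 (0.31 log units; beyond the scatter), so this change is tied to more compound being tolerated. That step is only a lower bound on the change, as compound 3 gives > 100000 nM, which is a limit of the assay and not a number. With this result, compound 1 remains the only compound in the series with a true number in this assay: the limit of > 100000 nM in this assay, at which 2 of the 3 values shown sit.

On these data alone, how far compound 3 lies past its limit remains unknown, and so does the full size of the step. The single change also removes a five-membered aromatic ring and adds a hydrogen-bond donor at once, so the compounds shown cannot separate the two, and they leave open how a carboxylic acid, an amine or a simple unsubstituted carbamoyl group would read at the same place.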